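Bis-benzimidazole series: methylphenyl position and a piperazine swap

The source may hold more compounds than are shown below. What is called first, only, known or untested is meant among the compounds shown, and "the series" means these compounds.

Measured in a functional assay on RPMI 8402 cells (Homo sapiens) for cytotoxicity; on this read-out lower numbers stand for stronger inhibition and higher numbers for weaker inhibition:

- compound 1, `Cc1ccccc1-c1nc2cc(-c3nc4cc(C#N)ccc4[nH]3)ccc2[nH]1`: compound 1 gives 1200 nM
- compound 2, `Cc1cccc(-c2nc3cc(-c4nc5cc(C#N)ccc5[nH]4)ccc3[nH]2)c1`: compound 2 gives 860 nM
- compound 3, `Cc1ccccc1-c1nc2cc(-c3nc4cc(N5CCN(C)CC5)ccc4[nH]3)ccc2[nH]1`: compound 3 gives 590 nM

Compound 1 and compound 2 differ by one change, (3-methylphenyl in place of 2-methylphenyl on an aromatic carbon), which gave a 1.4-fold lower number from compound 1 to compound 2 (0.14 log units; within the scatter). Compound 1 and compound 3 differ in the other half of the shared core, (4-methylpiperazin-1-yl in place of cyano on an aromatic carbon), which gave a 2.0-fold lower number from compound 1 to compound 3 (0.31 log units; beyond the scatter). Compound 3 has the lowest number of the three, but against compound 2 the gap is within the scatter, so no order between those two is claimed.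

Compound 4, `Cc1cccc(-c2nc3cc(-c4nc5cc(N6CCN(C)CC6)ccc5[nH]4)ccc3[nH]2)c1`, is not yet measured. It differs from compound 3 by 3-methylphenyl in place of 2-methylphenyl on an aromatic carbon. The place of this change is the same, word for word, as in the pair compound 1 to compound 2, so it is the same change made on the core of compound 3. Within the data shown here, the one earlier instance was within the scatter, so for this assay a step of about that size, a 1.4-fold lower number from compound 3 to compound 4 (0.14 log units; within the scatter), is expected from compound 3 to compound 4, resting on compound 1 to compound 2 giving a 1.4-fold lower number from compound 1 to compound 2 (0.14 log units; within the scatter). Compound 4 is therefore estimated at 430 nM, with a range from 200 nM to 900 nM.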

Compound 4, half-maximal inhibitory concentration: 360 nM
Beside the measured number, compound 4's estimate is 1.2-fold (0.08 log units) above it; the measured number falls inside the stated range.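

In this assay, 3-methylphenyl in place of 2-methylphenyl gave a 1.6-fold lower number from compound 3 to compound 4 (0.21 log units; within the scatter), and this agrees with the earlier step on the other core: the same change on two cores in this assay, a 1.4-fold lower number (0.14 log units; within the scatter) from compound 1 to compound 2 and a 1.6-fold lower number (0.21 log units; within the scatter) from compound 3 to compound 4, 1.2-fold (0.07 log units) apart, within the scatter of two such steps. The swap of cyano for 4-methylpiperazin-1-yl gave a 2.4-fold lower number from compound 2 to compound 4 (0.38 log units; beyond the scatter), a modest step that also carried over at about the same size: the same change on two cores in this assay, a 2.0-fold lower number (0.31 log units; beyond the scatter) from compound 1 to compound 3 and a 2.4-fold lower number (0.38 log units; beyond the scatter) from compound 2 to compound 4, 1.2-fold (0.07 log units) apart, within the scatter of two such steps. Within these four compounds the two changes therefore read as independent of each other, but each has been seen on only two cores, the methylphenyl step does not exceed the scatter on either, and nothing here shows that either step would hold on a different core or explains why it occurs.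

The compounds shown leave open whether 4-methylphenyl or unsubstituted phenyl would fit the same picture at that place. They also leave open whether a primary amine, a carboxylic acid or a piperazine with a longer chain in place of cyano would give a step of similar size.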